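A few compounds are considered here, and "the series" means these few. Any claim that something is new, unique, unknown or untested is made for them only; others in the source may bear on it.

Measured compounds in a toxicity assay on THP-1 cells (Homo sapiens) for cytotoxicity, read by MTT assay, with a stated time of 72 h; a lower number here means that less compound is needed, a higher number that more compound is needed for the effect:
Compound 1 `NC(=S)N/N=C/c1ccc(OCc2ccccc2)c2ccccc12` gives 27000 nM.
Compound 2 `COCOc1ccc(/C=N/NC(N)=S)c2ccccc12` gives only a limit of the assay, > 200000 nM.
Compound 3 `NC(=S)N/N=C/c1ccc2ccccc2c1OCc1ccccc1` gives 28000 nM.

Compound 4 `COCOc1c(/C=N/NC(N)=S)ccc2ccccc12` is not yet measured in this assay.

Compounds 1 and 3 are built from the same atoms joined differently; the difference between the two cores is not broken down here. In this assay compounds 1 and 3 give numbers that lie within the usual scatter of each other.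

Compound 2 differs from compound 1 by methoxy in place of phenyl on a saturated chain carbon bound to an oxygen on an aromatic ring. This change made an at least 7.4-fold higher number from compound 1 to compound 2 (0.86 log units; beyond the scatter). The value of compound 2 sits at the limit of > 200000 nM in this assay, at which 1 of the 3 values shown sits, so the full size of that step is not known.

Compound 4 differs from compound 3 by methoxy in place of phenyl on a saturated chain carbon bound to an oxygen on an aromatic ring, the same change at the same place. For the measured compounds named here, for compound 2 the single measured example of this change ended at a limit, and the same outcome is expected for compound 4, since compound 3 starts from a number close to that of compound 1. For compound 4 the expected step is a 7.1-fold higher number from compound 3 to compound 4 (0.85 log units; beyond the scatter). For compound 4 the estimate is 200000 nM. The expected range for compound 4 runs from 90000 nM to 450000 nM. A limit rather than a number is considered likely for compound 4.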

Compound 4, half-maximal effective concentration: 56000 nM
For compound 4 the middle estimate is 3.6-fold (0.55 log units) above the measured one; the whole stated range lies above it.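

In this assay, the change from benzyloxy to methoxymethoxy on the core of compound 3 gives a 2.0-fold higher number from compound 3 to compound 4 (0.30 log units; within the scatter) and does not repeat the step seen on the core of compound 1: the same change on two cores in this assay, an at least 7.4-fold higher number (0.86 log units; beyond the scatter) from compound 1 to compound 2 and a 2.0-fold higher number (0.30 log units; within the scatter) from compound 3 to compound 4, at least 3.7-fold (0.56 log units) apart, beyond the scatter of two such steps. These two pairs show only that the size of the step does not carry over unchanged between the two cores; they do not show what in the cores sets the steps apart, or how the change would run on any further core. From the compounds shown here alone, compound 2 stands at a limit of the assay, so the full size of its step stays unknown: the limit of > 200000 nM in this assay, at which 1 of the 4 values shown sits.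

The compounds shown hold only benzyloxy and methoxymethoxy at this place, so it remains open how an amine, a carboxylic acid or a longer chain would read in this assay on either core. Also open, going by these compounds, is where compound 2 would fall as a number, and with it how wide the gap between the two steps really is.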